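Bromo to Methoxy: Estimating Compound 3

The compounds below may be only part of what the source reports. "The series", "measured", "known", "first", "only" and "open" are said of these compounds alone.

Of the compounds shown here, two have so far been tested in a functional assay on A549 cells (Homo sapiens) for inhibition, read by MTT assay, with a stated time of 72 h; a higher number here means a weaker inhibitor, a lower number a stronger inhibitor. Compound 1 `COc1ccc(-n2cc(C(=O)Nc3ccc(Oc4ccnc5c4ccn5C)c(F)c3)c(=O)c3ccccc32)cc1` gives 3210 nM. Compound 2 `O=C(Nc1ccc(Oc2ccnc3[nH]ccc23)c(F)c1)c1cn(-c2ccc(Br)cc2)c2ccccc2c1=O` gives 950 nM, the lowest of the two numbers and beyond the usual scatter from compound 1. Compound 3 `COc1ccc(-n2cc(C(=O)Nc3ccc(Oc4ccnc5[nH]ccc45)c(F)c3)c(=O)c3ccccc32)cc1` differs from compound 2 by methoxy in place of bromo on an aromatic carbon. Among the compounds with values here, no step between measured compounds covers this swap alone; compound 1 also carries the methoxy group but differs from compound 3 in a second place too, so it only hints that the number may rise. Compound 3 is expected to give 1800 nM, with a likely range from 700 nM to 4500 nM, a modest step of a 1.9-fold higher number from compound 2 to compound 3 (0.28 log units; within the scatter) that may not exceed the scatter.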

Compound 3, half-maximal inhibitory concentration: 4150 nM
Compound 3: the middle estimate sits 2.3-fold (0.36 log units) below what was measured, within the range that was stated.
By their numbers in this assay, from the lowest: compound 2; then compounds 1 and 3 (each within the scatter of the next).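

In this assay, 4-methoxyphenyl in place of 4-bromophenyl gives a 4.4-fold higher number from compound 2 to compound 3 (0.64 log units; beyond the scatter), so the group para to a large group on this ring clearly affects the number. By contrast, hydrogen in place of methyl on the aromatic nitrogen gives only a 1.3-fold higher number from compound 1 to compound 3 (0.11 log units; within the scatter), so with methoxy present this second change shows no clear effect. Going by these compounds, whether an amine or a carboxylic acid at the same place would give a number nearer that of bromo or of methoxy stays open, as does how methyl on the aromatic nitrogen behaves with bromo present. Nothing measured here gives a reason for the step from bromo to methoxy.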